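Replacing methyl with 4-fluorophenyl on compound 1

This account rests on a few compounds, and the source may have more. Where it says the series, first, only, none or still open, it means among the compounds named here.

Going by the values given here, in a functional assay on DU-145 cells (Homo sapiens) for cytotoxicity, read by MTT assay, with a stated time of 48 h (on this read-out lower numbers stand for stronger inhibition and higher numbers for weaker inhibition), compound 1 (`COc1cc(COCc2cn(Cc3cc(C)cnc3Cl)nn2)cc(OC)c1OC`) gives 34800 nM, the lower of the two numbers so far, while compound 2 (`COc1cc(-c2cc(COCc3cn(Cc4cc(-c5ccccc5)cnc4Cl)nn3)on2)cc(OC)c1OC`) gives 78500 nM, a higher number beyond the scatter. Compound 3 (`COc1cc(COCc2cn(Cc3cc(-c4ccc(F)cc4)cnc3Cl)nn2)cc(OC)c1OC`) has not yet been measured. It carries 4-fluorophenyl in place of methyl on an aromatic carbon. Among the compounds with values here, no measured step isolates this change, so no shift beyond the scatter is expected, and the estimated step of a 1.3-fold higher number from compound 1 to compound 3 (0.12 log units; within the scatter) leans slightly toward weaker inhibition. The estimate for compound 3 is 46000 nM, with an expected range of 18000 nM to 100000 nM.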

Compound 3, half-maximal inhibitory concentration: 38800 nM
Compound 3: middle estimate off by 1.2-fold (0.07 log units), on the high side; the measured number falls inside the stated range.
By their numbers in this assay, from the lowest: compounds 1 and 3 (each within the scatter of the next); then compound 2.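

In this assay, the place para to the chloro group accepts 4-fluorophenyl in place of methyl with a 1.1-fold higher number from compound 1 to compound 3 (0.05 log units; within the scatter). A group of 7 heavy atoms with its own aromatic ring therefore stands where a single carbon stood, and the two numbers remain within the scatter of each other. No measured evidence accounts for this result. From the compounds shown here alone, whether an amine or a carboxylic acid at this place would give a number beyond the scatter remains open, as does whether a longer chain would.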